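One Halogen for Another on the Amide-Side Ring

A few compounds are considered here, and "the series" means these few. Any claim that something is new, unique, unknown or untested is made for them only; others in the source may bear on it.

For the measured compounds named here, in a functional assay on MDA-MB-231 cells (Homo sapiens) for inhibition, read by MTT assay, with a stated time of 72 h (a lower number here means a stronger inhibitor, a higher number a weaker inhibitor), compound 2 `O=C(CSc1nc(Nc2ccccc2)c2ccccc2n1)Nc1ccc(Cl)c(Cl)c1` gives 14500 nM, and the only other number so far belongs to compound 1 `O=C(CSc1nc(Nc2ccccc2)c2ccccc2n1)Nc1ccc([N+](=O)[O-])cc1`, which gives 16800 nM in this assay; the difference between them is a 1.2-fold lower number from compound 1 to compound 2 (0.06 log units; within the scatter). Compound 3 `O=C(CSc1nc(Nc2ccccc2)c2ccccc2n1)Nc1ccc(F)c(Cl)c1` differs from compound 2 by fluoro in place of chloro on an aromatic carbon. Going by the values given here, the single measured step also alters a substituent on this ring and stays within the scatter, so it gives no reason to expect a shift beyond the scatter here either. Compound 3 is therefore estimated at 14500 nM, with a range of 7000 nM to 30000 nM, which means an expected step of no change at the digits printed from compound 2 to compound 3 (within the scatter).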

Compound 3, half-maximal inhibitory concentration: 21600 nM
The estimate for compound 3 lay 1.5-fold (0.17 log units) below the measured number, within the range that was stated.
By their numbers in this assay, from the lowest: compounds 2, 1 and 3 (each within the scatter of the next).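

Fluoro and chloro are interchangeable at this position, para to a large group and ortho to a chloro group, as far as this assay can tell: the exchange gives a 1.5-fold higher number from compound 2 to compound 3 (0.17 log units; within the scatter). The wider exchange of the whole amide-side ring gives a 1.3-fold higher number from compound 1 to compound 3 (0.11 log units; within the scatter), so the three rings tested so far cannot be told apart in this assay, and a second kind of change on this ring has now also stayed within the scatter.

Going by these compounds, whether an amine, a carboxylic acid or a methoxy group at this position would move the number beyond the scatter remains open. No evidence on hand bears on this result.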